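A few compounds are considered here, and "the series" means these few. Any claim that something is new, unique, unknown or untested is made for them only; others in the source may bear on it.

In a functional assay on EL4 cells (Mus musculus) for inhibition, tested at 100 uM (a higher number here means more inhibition at the concentration tested (going by the name of the read-out), a lower number less inhibition), three members of one series have been examined so far, and none of them has yielded a number. Compound 1, `Clc1[nH]ccc2ncnc1-2`, sits at the limit of the assay, < 5%. Compound 2, `[N-]=[N+]=Nc1[nH]ccc2ncnc1-2`, sits at that same limit, < 5%. Compound 3, `CCNc1[nH]ccc2ncnc1-2`, likewise reaches only the limit, < 5%. Compound 3 therefore stands exactly where its two companions stand: all three values shown are limits, a fact summed up in the limit of < 5% in this assay, at which 3 of the 3 values shown sit. The steps among them cannot be sized: a step that the two limits leave unreadable from compound 1 to compound 2, a step that the two limits leave unreadable from compound 1 to compound 3 and a step that the two limits leave unreadable from compound 2 to compound 3 are each hidden by the two limits.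

Compound 4, `CSc1[nH]ccc2ncnc1-2`, continues from compound 3 by a single exchange. methylsulfanyl in place of ethylamino on an aromatic carbon Of the measured steps, only those that end at compound 3 bear on this move, and both are unreadable, so they supply no measured size in either direction; nothing among the shown values points to a change beyond the scatter in this assay. The estimated step is a step that the limit leaves unreadable from compound 3 to compound 4, meaning no shift that the assay would register. Compound 4 is accordingly expected to give 3% in this assay, somewhere between 0% and 15%, and most likely to be reported once more only as a limit.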

Compound 4, a percentage reported as inhibition, at one concentration (the size of the read-out at that concentration, not a potency): < 5%
Compound 4 was reported as a limit; the forecaster's own chance of this, stated with the estimate: 80%; the middle value is on the limit's open side.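

In this assay compound 4 gives < 5%, which is a limit and not a number. No new step can be read from compound 4 to compound 1, compound 2 or compound 3, and the series stays at one limit: the limit of < 5% in this assay, at which 4 of the 4 values shown sit. The compounds shown leave open whether any group in this place on the shared core gives inhibition that this assay can report as a number.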